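Dropping One Basic Side Chain: Expected Effect on Potency

This account rests on a few compounds, and the source may have more. Where it says the series, first, only, none or still open, it means among the compounds named here.

compound 1 `O=C(/C=C/c1ccc(OCCCCCCN2CCCC2)cc1)c1ccc(OCCCCCCN2CCCC2)cc1O`: 570 nM
compound 2 `CCN(CC)CCCCCCOc1ccc(/C=C/C(=O)c2ccc(OCCCCCCN(CC)CC)cc2O)cc1`: 1600 nM

In an assay on cells for inhibition of Amine oxidase [flavin-containing] B (Homo sapiens), read by fluorescence, with a stated time of 30 min (a higher number here means a weaker inhibitor, a lower number a stronger inhibitor), compound 1 gives 570 nM, the lower of the two measured numbers; compound 2 gives 1600 nM, and the gap between them lies beyond the usual scatter. Compound 3 `O=C(/C=C/c1ccccc1)c1ccc(OCCCCCCN2CCCC2)cc1O` differs from compound 1 by hydrogen in place of (6-(pyrrolidin-1-yl)hexyl)oxy on an aromatic carbon. Among the compounds with values here, no measured pair shows this kind of change, so the step can only be guessed. Because compound 1 carries two such chains and gives 570 nM, removing one is expected to weaken inhibition by a moderate step beyond the scatter, a 3.5-fold higher number from compound 1 to compound 3 (0.55 log units; beyond the scatter). Compound 3 is therefore estimated at 2000 nM, with a range from 600 nM to 7000 nM.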

Compound 3, half-maximal inhibitory concentration: 12700 nM
Compound 3: middle estimate off by 6.4-fold (0.80 log units), on the low side; the whole stated range lies below it.
By their numbers in this assay, from the lowest: compound 1; then compound 2; then compound 3.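

In this assay there is a 22-fold higher number from compound 1 to compound 3 (1.35 log units; beyond the scatter) when the (6-(pyrrolidin-1-yl)hexyl)oxy chain on this aromatic carbon gives way to hydrogen. This chain therefore matters greatly here, and the matching chain that compound 3 keeps does not make up for its loss. No measurement at hand accounts for the drop. Still open, going by these compounds, is whether a small methoxy group on this carbon would recover any of the lost strength, and whether a shorter chain ending in the same pyrrolidine ring would match the full chain.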